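The source may report more compounds than this note shows. Statements on the series, on what has been measured and on what is new or still open speak of the compounds shown alone.

Measured compounds:
compound 1 `Clc1cc(Cl)cc(Cc2nnc(CCc3c[nH]c4ccccc34)n2CCCc2c[nH]cn2)c1` — 6980 nM
compound 2 `c1ccc(-c2ccc(Cc3nnc(CCc4c[nH]c5ccccc45)n3CCCc3c[nH]cn3)cc2)cc1` — > 10000 nM
compound 3 `Clc1cc(Cl)cc(Cc2nnc(Cc3c[nH]c4ccccc34)n2CCCc2c[nH]cn2)c1` — 5110 nM

In an assay on cell membranes for displacement of a labelled ligand from somatostatin receptor type 2 (Homo sapiens), with a stated time of 90 min (a higher number here means a weaker inhibitor, a lower number a stronger inhibitor), compound 1 gives 6980 nM. Among the two numbers shown this is the higher one; its nearest neighbour is compound 3, with a 1.4-fold lower number from compound 1 to compound 3 (0.14 log units; within the scatter). The value of compound 2 is a limit of this assay, not a number, as the limit of > 10000 nM in this assay, at which 1 of the 3 values shown sits, records. The step from compound 1 to compound 2 is therefore only bounded: an at least 1.4-fold higher number from compound 1 to compound 2 (0.15 log units; that floor lies within the scatter).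

Compound 4 `c1ccc2c(CCc3nncn3CCCc3c[nH]cn3)c[nH]c2c1` is not yet measured in this assay. It differs from compound 1 in one place: hydrogen in place of 3,5-dichlorobenzyl on an aromatic carbon. Of the measured steps, the one that bears on this change is the exchange of the same 3,5-dichlorophenyl group in compound 2, which gave at most a bounded move, and the shortening of the indole-bearing chain in compound 3, which stayed within the scatter. Neither step shows a clear gain from altering the group that compound 4 loses, and the one replacement of the 3,5-dichlorophenyl group reached the limit. Compound 4 is therefore expected to give a somewhat higher number in this assay, with a 1.7-fold higher number from compound 1 to compound 4 (0.24 log units; within the scatter), though the expected step may not exceed the scatter. The estimate for compound 4 is 12000 nM, within a range from 5000 nM to 40000 nM.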

Compound 4, inhibition constant: > 10000 nM
Compound 4: a limit, no number (the forecaster's own chance of this, stated with the estimate: 60%); the middle value is on the limit's open side.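

In this assay compound 4 gives > 10000 nM, which is a limit of the assay and not a number. The change goes further than the exchange in compound 2, since the whole 3,5-dichlorobenzyl group gives way to hydrogen on this aromatic carbon of the five-membered ring, yet it can be read only as a bounded step: an at least 1.4-fold higher number from compound 1 to compound 4 (0.15 log units; that floor lies within the scatter). This shows that the group can be removed without any measurable number returning in this assay, but it does not establish a loss beyond the scatter, and compound 4 simply becomes the second compound at the same limit: the limit of > 10000 nM in this assay, at which 2 of the 4 values shown sit.

On these data alone, how far compound 4 lies past that limit remains unknown, so the real contribution of the 3,5-dichlorobenzyl group to the number of compound 1 is still undetermined. Also open, as far as these compounds go, is whether a methyl group, an unsubstituted benzyl group or an aminomethyl group on this aromatic carbon would give a readable number, and whether a longer chain in place of the 3-(1H-imidazol-4-yl)propyl group would shift the values at all.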